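A few compounds are considered here, and "the series" means these few. Any claim that something is new, unique, unknown or untested is made for them only; others in the source may bear on it.

Compound 1, `O=C(O)CC/C=C\CO[C@H]1C(OCc2ccc(-c3ccc(CO)cc3)cc2)CC[C@@H]1N1CCCCCC1`, gives 20 nM in a functional assay for antagonist activity at thromboxane A2 receptor (Rattus norvegicus); a lower number here means tighter binding, a higher number weaker binding. Compound 2, `CS(=O)(=O)Nc1cccc(-c2ccc(COC3CC[C@H](N4CCCCCC4)[C@H]3OC/C=C\CCC(=O)O)cc2)c1`, gives 50.1 nM. Compound 3, `O=C(O)CC/C=C\CO[C@H]1C(OCc2ccc(-c3ccccc3CCO)cc2)CC[C@@H]1N1CCCCCC1`, gives 31.6 nM.

Compound 3 lies within the usual scatter of both other values: a 1.6-fold higher number from compound 1 to compound 3 (0.20 log units; within the scatter) and a 1.6-fold lower number from compound 2 to compound 3 (0.20 log units; within the scatter). Compound 4, `CS(=O)(=O)Nc1ccccc1-c1ccc(COC2CC[C@H](N3CCCCCC3)[C@H]2OC/C=C\CCC(=O)O)cc1`, differs from compound 3 in one place: methanesulfonamido in place of 2-hydroxyethyl on an aromatic carbon. For the measured compounds named here, two measured steps bear on this. The step of a 1.6-fold lower number from compound 2 to compound 3 (0.20 log units; within the scatter) already set 3-(methanesulfonamido)phenyl against 2-(2-hydroxyethyl)phenyl, and the step of a 2.5-fold higher number from compound 1 to compound 2 (0.40 log units; beyond the scatter), where methanesulfonamido entered, was a modest rise. Taken together, the expected shift for compound 4 is small, leaning slightly toward a higher number: a 1.4-fold higher number from compound 3 to compound 4 (0.15 log units; within the scatter). Compound 4 is therefore expected to give about 45 nM, within a range from 18 nM to 120 nM.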

Compound 4, dissociation constant: 3.98 nM
The estimate for compound 4 lay 11-fold (1.05 log units) above the measured number; the measured number lies below the stated range.
By their numbers in this assay, from the lowest: compound 4; then compounds 1, 3 and 2 (each within the scatter of the next, the first and the last beyond it).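

In this assay the placement of methanesulfonamido matters: a 13-fold lower number from compound 2 to compound 4 (1.10 log units; beyond the scatter) comes with 2-(methanesulfonamido)phenyl in place of 3-(methanesulfonamido)phenyl. At this place on the ring the group also gives a 7.9-fold lower number from compound 3 to compound 4 (0.90 log units; beyond the scatter) when it replaces 2-hydroxyethyl, and a 5.0-fold lower number from compound 1 to compound 4 (0.70 log units; beyond the scatter) when the whole 2-(methanesulfonamido)phenyl group replaces 4-(hydroxymethyl)phenyl. No supporting measurement accounts for these drops.

From the compounds shown here alone, whether an amine, a carboxylic acid or an ethanesulfonamido group at this place would keep the number this low remains open. So does the effect of 4-(methanesulfonamido)phenyl.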